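Swapping Fluoro for Hydroxy on a Growth Inhibitor

This account rests on a few compounds, and the source may have more. Where it says the series, first, only, none or still open, it means among the compounds named here.

Compound 1 `Cn1c(=O)c(S(=O)(=O)c2ccc(OC(=O)CCCCC3SCC4NC(=O)NC43)cc2)cc2cnc(Nc3ccc4[nH]ccc4c3)nc21`: 750 nM
Compound 2 `Cn1c(=O)c(S(=O)(=O)c2ccc(F)cc2)cc2cnc(Nc3ccc4[nH]ccc4c3)nc21`: 100 nM

Both compounds were tested in a functional assay on NCI-H1975 cells (Homo sapiens) for inhibition, read by trypan blue exclusion, with a stated time of 72 h; a lower number here means a stronger inhibitor of growth, a higher number a weaker inhibitor of growth. Of the two, compound 2 has the lower number, 100 nM, which makes it the stronger inhibitor of growth. The gap between it and compound 1 lies beyond the scatter.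

The next compound, compound 3 `Cn1c(=O)c(S(=O)(=O)c2ccc(O)cc2)cc2cnc(Nc3ccc4[nH]ccc4c3)nc21`, keeps the shared core of compound 2 and changes one group: hydroxy in place of fluoro on an aromatic carbon. This puts hydroxy in place of fluoro on an aromatic carbon, para to a large group, so that 4-fluorophenyl becomes 4-hydroxyphenyl.

Among the measured compounds shown here, no two measured compounds differ in just one place, so the data offer no direct precedent. The closest guide is compound 1, which carries a much larger group on that ring and still gives 750 nM. A small step is expected in this assay, towards a slightly higher number and within the scatter. The expected change is an estimated 1.5-fold higher number from compound 2 to compound 3 (0.18 log units; within the scatter). For compound 3 the estimated value is 150 nM, with an expected range from 50 nM to 450 nM.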

Compound 3, concentration for 50% growth inhibition: 750 nM
Compound 3: the middle estimate sits 5.0-fold (0.70 log units) below what was measured; measured number above the stated range.
By their numbers in this assay, from the lowest: compound 2; then compounds 1 and 3 (each within the scatter of the next).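

In this assay, replacing fluoro with hydroxy exchanges one heavy atom for another, yet it gives a 7.5-fold higher number from compound 2 to compound 3 (0.88 log units; beyond the scatter), so even the smallest kind of swap on this ring can shift growth inhibition by more than the usual scatter. The comparison also shows that size alone does not set the number here: compound 3, with its single oxygen on the ring, gives 750 nM, and compound 1, with its much larger group on the same ring, gives 750 nM, two values that cannot be told apart. Nothing available explains why hydroxy gives the higher number in this pair.

Left open is whether the weaker result is tied to the hydrogen of the hydroxy group, which a methoxy group at the same place could help to test, since it keeps the oxygen but has no such hydrogen. An amine or a chlorine there would further show whether fluoro is unusual in giving the lower number, or whether other small groups give a similar value.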